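Replacing the Ethyl Group of Compound 2

The source may report more compounds than this note shows. Statements on the series, on what has been measured and on what is new or still open speak of the compounds shown alone.

In a functional assay on RKOp27 cells (Homo sapiens) for cytotoxicity, read by MTT assay, with a stated time of 3 days (on this read-out lower numbers stand for stronger inhibition and higher numbers for weaker inhibition), compound 1 `N#Cc1c(O)nc(SCc2nc3ccccc3[nH]2)nc1-c1ccccc1` gives 6.09 nM and compound 2 `CCNc1nc(SCc2nc3ccccc3[nH]2)nc(-c2ccccc2)c1C#N` gives 7.35 nM. Within the data shown here, these two values lie within the scatter of each other, so compound 2 stands level with compound 1 on the numbers so far.

Compound 3 `N#Cc1c(NNC(N)=S)nc(SCc2nc3ccccc3[nH]2)nc1-c1ccccc1` has not yet been measured. Its difference from compound 2 is this: a group of 4 heavy atoms (1 carbon, 2 nitrogen, 1 sulfur; no ring) in place of a group of 2 heavy atoms (2 carbon; no ring), on a nitrogen on an aromatic ring. The new group of 4 heavy atoms takes the place of ethyl on a nitrogen on an aromatic ring.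

Among the measured compounds shown here, only one measured step bears on this change. In a 1.2-fold higher number from compound 1 to compound 2 (0.08 log units; within the scatter), ethylamino takes the place of hydroxy on an aromatic carbon, and that step stays within the scatter. For the measured compounds named here, it offers only indirect guidance, as no measured step changes a group on that nitrogen. Going by the values given here, the single step therefore gives no reason to expect a shift in either direction, although it cannot rule one out.

The expected step is a 1.1-fold lower number from compound 2 to compound 3 (0.02 log units; within the scatter), which would be none beyond the scatter. For compound 3 the estimated value is 7 nM, with an expected range of 2.5 nM to 20 nM.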

Compound 3, half-maximal inhibitory concentration: 3.2 nM
For compound 3 the middle estimate is 2.2-fold (0.34 log units) above the measured one, and the stated range covers the measured number.
By their numbers in this assay, from the lowest: compounds 3, 1 and 2 (each within the scatter of the next, the first and the last beyond it).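

In this assay, the nitrogen on an aromatic ring proves sensitive to what it carries: the group of 4 heavy atoms in place of ethyl gives a 2.3-fold lower number from compound 2 to compound 3 (0.36 log units; beyond the scatter) and is the only step shown that lies beyond the scatter. That gain holds against ethyl alone, for the comparison with hydroxy on the aromatic carbon gives a 1.9-fold lower number from compound 1 to compound 3 (0.28 log units; within the scatter) and so does not separate the group now on that carbon from hydroxy. The entering group brings 2 hydrogen-bond donors and 1 hydrogen-bond acceptor where ethyl has none, but no measurement shown ties the step to those counts or to anything else about the group.

From the compounds shown here alone, it remains open whether the whole of the new group is needed, since a plain hydrazine on that aromatic carbon, or the same group with oxygen in place of its sulfur, could tell how much the thiocarbonyl contributes. Going by these compounds, it is equally open whether a longer chain such as propyl, or a small ring such as cyclopropyl, on that nitrogen would move the number in either direction.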